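Stilbene phenols: amino for methoxy on the far ring

The source may hold more compounds than are shown below. What is called first, only, known or untested is meant among the compounds shown, and "the series" means these compounds.

Measured so far in a functional assay on MCF7 cells (Homo sapiens) for inhibition, read by MTT assay, with a stated time of 2 days; on this read-out higher numbers stand for weaker inhibition and lower numbers for stronger inhibition:
compound 1, `Nc1ccccc1/C=C/c1cccc(O)c1`, gives 17 ug/mL;
compound 2, `COc1ccc(/C=C/c2ccccc2O)cc1`, gives 17 ug/mL;
compound 3, `COc1ccccc1/C=C/c1cccc(O)c1`, gives 24.3 ug/mL.

Compound 1 and compound 2 stand level at the digits shown, and compound 3 sits within the scatter of both, so no order among the three can be read from these numbers.

One single-point change is covered: from compound 3 to compound 1, (amino in place of methoxy on an aromatic carbon). The step is a 1.4-fold lower number from compound 3 to compound 1 (0.16 log units; within the scatter). Compound 2 and compound 3 are built from the same atoms joined differently; the difference between the two cores is not broken down here.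

Compound 4, `Nc1ccc(/C=C/c2ccccc2O)cc1`, is not yet measured. From compound 2 it differs as amino in place of methoxy on an aromatic carbon. This is the same kind of change as from compound 3 to compound 1, not the same: there the place is ortho to a group of 9 heavy atoms, here it is para to a group of 9 heavy atoms.

Within the data shown here, the expectation for compound 4 rests on compound 2 at 17 ug/mL and on the one measured step of this kind, a 1.4-fold lower number from compound 3 to compound 1 (0.16 log units; within the scatter), which lies within the scatter. The step is expected to be small, a 1.2-fold lower number from compound 2 to compound 4 (0.08 log units; within the scatter), of the same order as that earlier one. Compound 4 is expected to give 14 ug/mL in this assay, with a likely range from 7 ug/mL to 30 ug/mL.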

Compound 4, half-maximal inhibitory concentration: 23 ug/mL
Compound 4: the middle estimate sits 1.6-fold (0.22 log units) below what was measured, within the range that was stated.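

In this assay, amino in place of methoxy on an aromatic carbon, para to a group of 9 heavy atoms, gives a 1.4-fold higher number from compound 2 to compound 4 (0.13 log units; within the scatter), so on the core of compound 2 this change leaves the number inside the usual spread of repeated measurements. Set beside the step on the other core, the new step does not separate from it: the same change on two cores in this assay, a 1.4-fold lower number (0.16 log units; within the scatter) from compound 3 to compound 1 and a 1.4-fold higher number (0.13 log units; within the scatter) from compound 2 to compound 4, 1.9-fold (0.29 log units) apart, within the scatter of two such steps

Across these two cores, then, the change can be carried over only in the limited sense that neither step can be told from no change at all; the opposite directions printed for the two steps carry no weight, and no consistent direction can be claimed, whether for or against, nor can any influence of the core or of the place on the ring be read from this pair.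

What the compounds shown leave open is whether any group on this carbon moves the number beyond the scatter in this assay, for instance a carboxylic acid, a nitrile or a longer chain such as butoxy in place of methoxy. Also open, going by these compounds, is whether a larger step would then repeat from one core to the other, which two steps this small cannot test.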